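The source may report more compounds than this note shows. Statements on the series, on what has been measured and on what is new or still open speak of the compounds shown alone.

Compound 1 `O=C(/C=C/c1ccc([N+](=O)[O-])cc1)Nc1cc2c(Nc3ccc(F)c(Cl)c3)ncnc2cc1O[C@H]1CCOC1` — 12000 nM
Compound 2 `COc1cc(/C=C/C(=O)Nc2cc3c(Nc4ccc(F)c(Cl)c4)ncnc3cc2O[C@H]2CCOC2)cc(OC)c1O` — 27000 nM

Of the compounds shown here, two have been measured in a functional assay on A549 cells (Homo sapiens) for cytotoxicity, read by MTT assay, with a stated time of 72 h; a higher number here means a weaker inhibitor, a lower number a stronger inhibitor. Compound 1 gives the lower of the two numbers; its nearest neighbour is compound 2, reached by a 2.3-fold higher number from compound 1 to compound 2 (0.35 log units; beyond the scatter). Compound 3 `COc1cc(/C=C/C(=O)Nc2cc3c(Nc4ccc(F)c(Cl)c4)ncnc3cc2O[C@H]2CCOC2)cc(OC)c1` has not yet been measured. It differs from compound 1 in one place: 3,5-dimethoxyphenyl in place of 4-nitrophenyl on a double-bonded chain carbon bound to a double-bonded chain carbon. Among the measured compounds shown here, the one measured step that bears on this change is the one in which a 4-hydroxy-3,5-dimethoxyphenyl replaced the 4-nitrophenyl and gave a 2.3-fold higher number from compound 1 to compound 2 (0.35 log units; beyond the scatter). For the measured compounds named here, compound 3 carries the same ring lacking only the hydroxy, so a modest step in the same direction is expected, though no measured pair isolates the hydroxy on its own. Compound 3 is therefore estimated to come in at 22000 nM, with a range of 9000 nM to 50000 nM. The step expected from this is a 1.8-fold higher number from compound 1 to compound 3 (0.26 log units; within the scatter).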

Compound 3, half-maximal inhibitory concentration: 10800 nM
Beside the measured number, compound 3's estimate is 2.0-fold (0.31 log units) above it; the measured number falls inside the stated range.
By their numbers in this assay, from the lowest: compounds 3 and 1 (each within the scatter of the next); then compound 2.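

In this assay, 3,5-dimethoxyphenyl in place of 4-nitrophenyl on a double-bonded chain carbon gives a 1.1-fold lower number from compound 1 to compound 3 (0.05 log units; within the scatter), so this assay does not separate these two groups at this position. Compound 3 also supplies the pair that isolates the hydroxy: hydrogen in place of hydroxy on an aromatic carbon gives a 2.5-fold lower number from compound 2 to compound 3 (0.40 log units; beyond the scatter), which ties the higher number of compound 2 to the hydroxy and not to the two methoxy groups. Nothing shown here offers a reason for either step.

Going by these compounds, all three compounds carry a substituted phenyl ring at this place, so it remains open how a piperidine, a carboxylic acid or a longer chain would read in this assay. On these data alone, it is also open whether the hydroxy step would hold on a 4-hydroxyphenyl group without the methoxy groups.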